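The compounds below may be only part of what the source reports. "The series", "measured", "known", "first", "only" and "open" are said of these compounds alone.

Working notes on the series. In a functional assay on Hs-578T cells (Homo sapiens) (a lower number here means a stronger inhibitor of growth, a higher number a weaker inhibitor of growth), compound 1 `COc1cc(CSc2cc(Cl)c(-c3nc(-c4ccc(Cl)cc4)no3)cc2S(=O)(=O)NC(=N)NO)cc(OC)c1OC` gives 4170 nM. Among the measured compounds shown here, of the two numbers measured so far this is the higher one, but the only neighbour, compound 2 `N=C(NO)NS(=O)(=O)c1cc(-c2nc(-c3ccccc3)no2)c(Cl)cc1SCc1ccccc1`, gives 2550 nM in this assay, and the gap between them lies within the scatter, so the two cannot be ranked. Compound 3 `COc1cc(CSc2cc(Cl)c(-c3nnc(-c4ccc(Cl)cc4)s3)cc2S(=O)(=O)NC(=N)NO)cc(OC)c1OC` is not yet measured. Relative to compound 1 the change is 5-(4-chlorophenyl)-1,3,4-thiadiazol-2-yl in place of 3-(4-chlorophenyl)-1,2,4-oxadiazol-5-yl on an aromatic carbon. For the measured compounds named here, no step between measured compounds involves this change, so no direction is indicated; the expected shift from compound 1 to compound 3 is a 1.1-fold lower number from compound 1 to compound 3 (0.04 log units; within the scatter), that is none beyond the scatter. Compound 3 is therefore estimated at 3800 nM in this assay, with a range from 1500 nM to 10000 nM.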

Compound 3, concentration for 50% growth inhibition: 8130 nM
For compound 3 the middle estimate is 2.1-fold (0.33 log units) below the measured one; the range from low to high includes it.
By their numbers in this assay, from the lowest: compounds 2, 1 and 3 (each within the scatter of the next, the first and the last beyond it).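

In this assay, 5-(4-chlorophenyl)-1,3,4-thiadiazol-2-yl in place of 3-(4-chlorophenyl)-1,2,4-oxadiazol-5-yl gives a 1.9-fold higher number from compound 1 to compound 3 (0.29 log units; within the scatter) and so does not separate the two compounds. Among the compounds shown here, this is the first reading at this aromatic carbon: one five-membered aromatic ring with 3 hetero atoms, holding sulfur instead of oxygen, can replace the other without a change beyond the scatter. No measurement on hand explains this result. Still open, from the compounds shown here alone, is whether an amide at this carbon would do the same, and whether an amine or a carboxylic acid could replace the 4-chlorophenyl group.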